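Thiazolyl Ring for Chlorine at the Toxicity Ceiling

This account rests on a few compounds, and the source may have more. Where it says the series, first, only, none or still open, it means among the compounds named here.

Compound 1, `COC(=O)N[C@H](C(=O)NN(CCC[C@@](O)(Cc1ccccc1)C(=O)N[C@H]1c2ccccc2C[C@H]1O)Cc1ccc(Cl)cc1)C(C)(C)C`, gives > 10000 nM in an ADME assay on MT4 cells (Homo sapiens) for cytotoxicity; on this read-out higher numbers stand for lower toxicity in this test and lower numbers for higher toxicity in this test.
Compound 2, `COC(=O)N[C@H](C(=O)NN(CCC[C@@](O)(Cc1ccccc1)C(=O)N[C@H]1c2ccccc2C[C@H]1O)Cc1ccc(Br)cc1)C(C)(C)C`, gives > 10000 nM.
Compound 3, `COC(=O)N[C@H](C(=O)NN(CCC[C@@](O)(Cc1ccccc1)C(=O)N[C@H]1c2ccccc2C[C@H]1O)CC(C)C)C(C)(C)C`, gives > 10000 nM.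

The value for compound 1 is a limit of this assay, not a measured number. The value for compound 2 is likewise a limit. The value for compound 3 is a limit as well. Compound 1 therefore stands at the top edge of what this assay reports, and the two other compounds sit there with it, as summed up in the limit of > 10000 nM in this assay, at which 3 of the 3 values shown sit.

The three steps among the measured compounds tell nothing about size: a step that the two limits leave unreadable from compound 1 to compound 2, a step that the two limits leave unreadable from compound 1 to compound 3 and a step that the two limits leave unreadable from compound 2 to compound 3.

Compound 4, `COC(=O)N[C@H](C(=O)NN(CCC[C@@](O)(Cc1ccccc1)C(=O)N[C@H]1c2ccccc2C[C@H]1O)Cc1ccc(-c2nccs2)cc1)C(C)(C)C`, is not yet measured. It differs from compound 1 by 1,3-thiazol-2-yl in place of chloro on an aromatic carbon. Among the measured compounds shown here, no measured step involves this change, so the only guide is that compound 1 sits at the limit with > 10000 nM and that every recorded change around it has left the read-out at that limit. The step from compound 1 is expected to be unreadable once more, a number no higher from compound 1 to compound 4 (the limit leaves the size open), with compound 4 most likely reported again as a limit. The estimate for compound 4 is 10000 nM, with a range from 3000 nM to 30000 nM.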

Compound 4, half-maximal cytotoxic concentration: > 10000 nM
Compound 4: a limit, no number (the forecaster's own chance of this, stated with the estimate: 75%); the middle value lies on the limit itself.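

In this assay compound 4 gives > 10000 nM, which is a limit of the assay and not a number. Compound 1, compound 2 and compound 3 sit at the same limit, so none of the steps to compound 4 can be read. The compounds shown leave open whether these four differ from one another in toxicity at all.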